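The source may hold more compounds than are shown below. What is called first, only, known or untested is meant among the compounds shown, and "the series" means these compounds.

Measured compounds in this series:

compound 1 `NC(=O)CC[C@H](NC(=O)CN(c1ncnc2c1ncn2C1CCCCO1)C1CC1)C(=O)OCc1ccccc1` — 22.3%
compound 2 `CC[C@H](C)[C@H](NC(=O)CN(c1nc(Cl)nc2[nH]cnc12)C1CC1)C(=O)O` — 21.4%
compound 3 `C[C@@H](O)[C@H](NC(=O)CN(c1nc(Cl)nc2[nH]cnc12)C1CC1)C(=O)O` — 37.6%

All three numbers come from a functional assay on the whole organism (Tail, strain ICR) with Mus musculus as the target, in the tail flick test, with a stated time of 120 min, at a dose of 25 umol/kg by the oral route; on this read-out higher numbers stand for a stronger effect at the one dose given and lower numbers for a weaker effect. Compound 1 stands second highest of the three; compound 2 lies within the scatter of it, so no order between compound 1 and compound 2 can be read, while compound 3 sits beyond the scatter above compound 1. Among the measured compounds shown here, no computed step links compound 1 to compound 3, so only the two values themselves are to be noted.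

Compound 4 `NC(=O)C[C@H](NC(=O)CN(c1ncnc2c1ncn2C1CCCCO1)C1CC1)C(=O)OCc1ccccc1` is not yet measured. It differs from compound 1 as follows: carbamoyl in place of carbamoylmethyl on a saturated chain carbon, two bonds along the chain from an amide-type nitrogen and a carbonyl carbon. For the measured compounds named here, the one measured step, a number 16.2 percentage points higher from compound 2 to compound 3 (beyond the scatter), concerns a different exchange on a different core and carries no direct bearing on the shortening of a side chain by a single carbon on the core of compound 1. There is therefore nothing in the data that points to a change beyond the scatter in this assay for this step, in either direction.

The expected step is a number 0.3 percentage points lower from compound 1 to compound 4 (within the scatter). Going by the values given here, compound 4 is accordingly estimated at 22%, with a range from 8% to 38%, the range being wide since no measured step informs the estimate.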

Compound 4, a percentage reported as activity, at one dose (the size of the read-out at that dose, not a potency): 29.2%
For compound 4 the middle estimate is 7.2 percentage points below the measured one, and the stated range covers the measured number.
By their numbers in this assay, from the lowest: compounds 2, 1, 4 and 3 (each within the scatter of the next, the first and the last beyond it).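

In this assay, carbamoyl in place of carbamoylmethyl on a saturated chain carbon, two bonds along the chain from an amide-type nitrogen and a carbonyl carbon, gives a number 6.9 percentage points higher from compound 1 to compound 4 (within the scatter), so no order can be read between the two compounds. Among the compounds shown here, this is the first step at this position and the first on the core of compound 1; at the one dose and time given, the read-out does not separate 2-carbamoylethyl from carbamoylmethyl. No supporting data bear on this result.

On these data alone, it remains open whether a carboxylic acid or an amine at the end of this side chain, or a chain longer than 2-carbamoylethyl, would give a step beyond the scatter on the core of compound 1. As far as these compounds go, it is also open whether the hydroxy exchange in a number 16.2 percentage points higher from compound 2 to compound 3 (beyond the scatter) would give a step of similar size on that core, since this step stands only on the core shared by its own two compounds.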